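Propylamino in place of the amidine-like group on the shared core

This account rests on a few compounds, and the source may have more. Where it says the series, first, only, none or still open, it means among the compounds named here.

Measured compounds:
Compound 1 `Cc1nc2c(OCc3ccccc3)ccc(C)n2c1C` gives 8 mg/kg in a functional assay on the whole organism with Rattus norvegicus as the target; a higher number here means that more compound is needed for the effect, a lower number that less compound is needed.
Compound 2 `Cc1nc2c(OCc3ccccc3)cccn2c1/N=C/N(C)C` gives 9.8 mg/kg in this assay.

Two compounds have numbers in this assay. Compound 2 holds one of them, and its number and that of compound 1 lie within the scatter of each other, so the two cannot be told apart on this read-out. Among the compounds with values here, nothing separates the pair beyond the structural differences visible in their structures, and no step between them can be given.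

Compound 3 `CCCNc1c(C)nc2c(OCc3ccccc3)cccn12` is not yet measured. It differs from compound 2 by a group of 4 heavy atoms (3 carbon, 1 nitrogen; no ring) in place of a group of 5 heavy atoms (3 carbon, 2 nitrogen; no ring), on an aromatic carbon. Within the data shown here, no measured pair shows what such a change does in this assay, so the expectation rests only on the closeness of compound 1 and compound 2. He expects the step of a 1.1-fold lower number from compound 2 to compound 3 (0.04 log units; within the scatter) to stay within the scatter, in no fixed direction. For compound 3 he estimates 9 mg/kg, with a range from 4 mg/kg to 22 mg/kg.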

Compound 3, dose for half-maximal effect: 5.3 mg/kg
Estimate against measurement, compound 3: 1.7-fold (0.23 log units) above, and the stated range covers the measured number.
By their numbers in this assay, from the lowest: compounds 3, 1 and 2 (each within the scatter of the next).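

Within the data shown here, the position is the aromatic carbon of the five-membered aromatic ring with 2 nitrogen, and until now no step had been available there. Compound 3 provides the first one: propylamino in place of the amidine-like group gives a 1.8-fold lower number from compound 2 to compound 3 (0.27 log units; within the scatter) in this assay as the read-out. The change removes the double bond outside the aromatic rings and brings in a hydrogen-bond donor, yet the numbers of the pair still cannot be told apart, so the group at this carbon can differ in this way without a step beyond the scatter. Nothing measured here bears on why the two numbers stand as they do.

Going by these compounds, whether the same holds for other groups on this carbon remains open: a shorter chain such as ethylamino, a longer chain such as butylamino or hexylamino, or the unsubstituted amine could each stay close or move away in this assay as the read-out. Also open, on these data alone, is whether an acetamide or a carboxylic acid at this place would give a step beyond the scatter, and a single step cannot settle any trend along such a series.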